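Aryl sulfonyl variation on the bromobenzylamine hexyl linker

A few compounds are considered here, and "the series" means these few. Any claim that something is new, unique, unknown or untested is made for them only; others in the source may bear on it.

Two analogues of the shared core have been run in a functional assay on MIA PaCa-2 cells (Homo sapiens) for inhibition, read by MTT assay, with a stated time of 72 h; a lower number here means a stronger inhibitor of growth, a higher number a weaker inhibitor of growth. Compound 1 `O=S(=O)(NCCCCCCNCc1ccc(Br)cc1)c1cc(Cl)cc(Cl)c1` gives 12000 nM, and compound 2 `O=S(=O)(NCCCCCCNCc1ccc(Br)cc1)c1ccc2ccsc2c1` gives 6000 nM. Compound 2 is not separated from compound 1 on these numbers: the step of a 2.0-fold lower number from compound 1 to compound 2 (0.30 log units; within the scatter) does not clear the scatter, so the two aryl groups on the sulfonyl sulfur are so far indistinguishable.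

Compound 3 `Cc1ccc(C)c(S(=O)(=O)NCCCCCCNCc2ccc(Br)cc2)c1` continues the same exchange on the sulfonyl sulfur: 2,5-dimethylphenyl in place of 1-benzothiophen-6-yl on a sulfonyl sulfur. For the measured compounds named here, the only measured step that bears on this position, a 2.0-fold lower number from compound 1 to compound 2 (0.30 log units; within the scatter), was within the scatter, and no other sulfonyl aryl has been tested. On that basis the expected change in this assay is none beyond the scatter; the estimated step is a 1.3-fold higher number from compound 2 to compound 3 (0.12 log units; within the scatter). Compound 3 is therefore expected to give about 8000 nM, with a plausible range from 3000 nM to 25000 nM.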

Compound 3, concentration for 50% growth inhibition: 12000 nM
For compound 3 the middle estimate is 1.5-fold (0.18 log units) below the measured one; the measured number falls inside the stated range.
By their numbers in this assay, from the lowest: compounds 2, 1 and 3 (each within the scatter of the next).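

In this assay, 2,5-dimethylphenyl on a sulfonyl sulfur is not separated from either earlier aryl group, with a 2.0-fold higher number from compound 2 to compound 3 (0.30 log units; within the scatter) and no change at the digits printed from compound 1 to compound 3 (within the scatter) both printed as within the scatter. Leaving 1-benzothiophen-6-yl removes the five-membered aromatic ring and its hetero atom without a step that clears the scatter, and the exchange of 3,5-dichlorophenyl for 2,5-dimethylphenyl likewise gives no such step, so the three aryl groups remain indistinguishable at this position. No evidence is available to explain these numbers.

Still open, as far as these compounds go, is whether a pyridyl group, or a phenyl carrying an amine or a carboxylic acid, on the sulfonyl sulfur would give a step beyond the scatter. Also open, from the compounds shown here alone, is whether this position would stay as flat with a longer chain in place of the hexyl linker.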